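A few compounds are considered here, and "the series" means these few. Any claim that something is new, unique, unknown or untested is made for them only; others in the source may bear on it.

Of the compounds shown here, three built on one shared core have been measured so far. Compound 1 `Nc1cc(N)c2nc(-c3ccccc3)c(NCc3ccc(Cl)c(Cl)c3)nc2c1` gives 15500 nM in a functional assay on SF-295 cells (Homo sapiens) for inhibition, read by sulforhodamine B assay, with a stated time of 48 h; a lower number here means a stronger inhibitor of growth, a higher number a weaker inhibitor of growth. Compound 2 `Nc1cc(N)c2nc(-c3ccccc3)c(Sc3ccc(F)cc3)nc2c1` gives 13800 nM in this assay, and compound 3 `COc1cc(CNc2nc3cc(N)cc(N)c3nc2-c2ccccc2)cc(OC)c1OC` gives 1660 nM. Compound 2 thus holds the second highest number of the three: compound 1 stands nearest, within the usual scatter, while compound 3 lies furthest off, beyond it. Compound 4 `Nc1cc(N)c2nc(-c3ccccc3)c(Sc3ccc(Cl)c(Cl)c3)nc2c1` has not yet been measured. Against compound 2 the change is this: 3,4-dichlorophenyl in place of 4-fluorophenyl on a sulfur. Within the data shown here, no measured pair shows that change on its own, so the expectation rests on the values above. In this assay only a modest step is expected, a lowering that may well stay within the scatter. Compound 4 is therefore estimated at 10000 nM, between 3500 nM and 28000 nM, an expected step of a 1.4-fold lower number from compound 2 to compound 4 (0.14 log units; within the scatter).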

Compound 4, concentration for 50% growth inhibition: 17800 nM
Compound 4: middle estimate off by 1.8-fold (0.25 log units), on the low side; low and high end bracket the measured number.
By their numbers in this assay, from the lowest: compound 3; then compounds 2, 1 and 4 (each within the scatter of the next).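

Among these compounds, this is the first direct comparison on this sulfur: 3,4-dichlorophenyl in place of 4-fluorophenyl gives a 1.3-fold higher number from compound 2 to compound 4 (0.11 log units; within the scatter) in this assay. Adding a second halogen and changing fluorine to chlorine therefore leaves the number within the scatter, so this assay does not separate these two groups. No measurement shown here offers an explanation for this result.

Both groups on the sulfur carry halogen, so the compounds shown leave open whether plain phenyl or 4-methoxyphenyl there would give a different number. A carboxylic acid on that ring also remains an open case.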